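The source may report more compounds than this note shows. Statements on the series, on what has been measured and on what is new or still open speak of the compounds shown alone.

In an ADME assay on MT4 cells (Homo sapiens) for cytotoxicity, with a stated time of 5 days (a higher number here means that more compound is tolerated, a lower number that less compound is tolerated), compound 1 (`CC(C)(C)C#Cc1cc(N(C(=O)[C@H]2CC[C@H](C)CC2)[C@H]2CC[C@H](Oc3ccc4nccn4n3)CC2)c(C(=O)O)s1`) gives > 20000 nM, which is a limit of the assay and not a number. Compound 3 (`CC(C)(C)C#Cc1cc(N(C(=O)[C@H]2CC[C@H](C)CC2)[C@H]2CC[C@@H](Oc3ccc(=O)[nH]n3)CC2)c(C(=O)O)s1`) gives > 20000 nM, again a limit. Compound 2 (`CC1CC=C(C(=O)N(c2cc(C#CC(C)(C)C)sc2C(=O)O)C(C)C)CC1`) gives > 20000 nM, also a limit. Compound 2 therefore stands with the other two, and the whole set so far sits at one place: the limit of > 20000 nM in this assay, at which 3 of the 3 values shown sit.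

Compound 4 (`CC(C)N(C(=O)C1CCCCC1)c1cc(C#CC(C)(C)C)sc1C(=O)O`) differs from compound 2 in one place, with cyclohexyl in place of 4-methylcyclohex-1-en-1-yl on a carbonyl carbon. Going by the values given here, no tested pair shows what this swap does. Compound 2 offers only its limit of > 20000 nM as a starting point, so no shift in either direction is expected beyond the usual scatter of this assay. The expected step that the limit leaves unreadable from compound 2 to compound 4 is accordingly a small one. For compound 4 the estimated half-maximal cytotoxic concentration is 25000 nM, with an expected range from 12000 nM to 50000 nM, and the assay may well report only a limit again.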

Compound 4, half-maximal cytotoxic concentration: > 20000 nM
Compound 4 was reported as a limit; the forecaster's own chance of this, stated with the estimate: 85%; the middle value does not contradict the limit.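

Compound 2 and compound 4 are both reported only as a limit of the assay, so no step can be read between them. The compounds shown leave open whether cyclohexyl in place of 4-methylcyclohex-1-en-1-yl changes the half-maximal cytotoxic concentration in this assay, as all values share one ceiling: the limit of > 20000 nM in this assay, at which 4 of the 4 values shown sit.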